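Bromo for methoxy: from compound 3 to compound 4

The compounds below may be only part of what the source reports. "The series", "measured", "known", "first", "only" and "open" are said of these compounds alone.

Among the compounds with values here, in a functional assay on HL-60 cells (Homo sapiens) for cytotoxicity, read by luminescence and CellTiter-Glo, with a stated time of 3 days (a higher number here means a weaker inhibitor, a lower number a stronger inhibitor), compound 3 (`COc1ccc(C(=O)Nc2ccc(C#N)cc2)c(O)c1`) gives 5470 nM, the highest of the three numbers so far. Compound 2 (`N#Cc1ccc(NC(=O)c2ccc(Cl)cc2O)cc1`) gives 1300 nM. Compound 1 (`N#Cc1ccc(NC(=O)c2ccc(Br)cc2O)c(Cl)c1`), which carries bromo on a core with an added chloro, gives 730 nM. Compound 4 (`N#Cc1ccc(NC(=O)c2ccc(Br)cc2O)cc1`) is not yet measured and has bromo in place of methoxy on an aromatic carbon. The closest evidence is the modest chloro-to-methoxy step, a 4.2-fold higher number from compound 2 to compound 3 (0.62 log units; beyond the scatter), which the new change would roughly reverse with a different halogen. A lower number of similar size is therefore expected: a 4.6-fold lower number from compound 3 to compound 4 (0.66 log units; beyond the scatter). Compound 4 is estimated at 1200 nM, with an expected range of 600 nM to 2400 nM.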

Compound 4, half-maximal inhibitory concentration: 1210 nM
For compound 4 the middle estimate is 1.0-fold (0.00 log units) below the measured one, and the stated range covers the measured number.
By their numbers in this assay, from the lowest: compounds 1, 4 and 2 (each within the scatter of the next); then compound 3.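

In this assay, the two halogens cannot be told apart at this position: bromo for chloro gives a 1.1-fold lower number from compound 2 to compound 4 (0.03 log units; within the scatter), whereas bromo for methoxy gives a 4.5-fold lower number from compound 3 to compound 4 (0.66 log units; beyond the scatter), so among the three groups shown, methoxy alone stands apart. Removing the added chloro from the core of compound 1 also stays inside the scatter, with a 1.7-fold higher number from compound 1 to compound 4 (0.22 log units; within the scatter). No measured evidence explains either the methoxy gap or the halogen match.

As far as these compounds go, whether an amine, a carboxylic acid or a longer alkoxy chain at this position would track the halogens or methoxy remains open. Fluoro and iodo also remain untested here within this small set.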